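Dimethylamino for pyrrolidin-1-yl in the ester series

The source may hold more compounds than are shown below. What is called first, only, known or untested is meant among the compounds shown, and "the series" means these compounds.

Measured in an ADME assay on L6 cells (Rattus norvegicus) for cytotoxicity; a higher number here means a weaker inhibitor, a lower number a stronger inhibitor:
- compound 1 `CN1CCN(CCCN2CCC3(N(C)C)CC(c4ccccc4)C2C(c2ccccc2)C3)CC1`: 54500 nM
- compound 2 `CN1CCN(CCC(=O)OC2CC3(N4CCCC4)CC(c4ccccc4)C2C(c2ccccc2)C3)CC1`: 21300 nM

Compound 2 holds the lower number of the two, and its gap to compound 1 lies beyond the scatter. Two values say little about the series as a whole.

Still unmeasured is compound 3 `CN1CCN(CCC(=O)OC2CC3(N(C)C)CC(c4ccccc4)C2C(c2ccccc2)C3)CC1`. It carries dimethylamino in place of pyrrolidin-1-yl on a saturated ring carbon, and the rest of compound 2 stays as it is. Among the measured compounds shown here, no measured pair isolates this change, so any expected direction rests on thin evidence. Compound 1, which also carries dimethylamino, gives 54500 nM in this assay, but it differs from compound 2 in more than one place. Expected is a small step of a 1.4-fold higher number from compound 2 to compound 3 (0.15 log units; within the scatter), leaning to a higher number and likely within the scatter. For compound 3 the estimated value is 30000 nM, with an expected range of 13000 nM to 70000 nM.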

Compound 3, half-maximal inhibitory concentration: 31100 nM
Beside the measured number, compound 3's estimate is 1.0-fold (0.02 log units) below it; the range from low to high includes it.
By their numbers in this assay, from the lowest: compounds 2, 3 and 1 (each within the scatter of the next, the first and the last beyond it).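

In this assay, the exchange of pyrrolidin-1-yl for dimethylamino on the saturated ring carbon, in the ester series with the rest of compound 2 held fixed, gives a 1.5-fold higher number from compound 2 to compound 3 (0.16 log units; within the scatter). Among the compounds shown here, this is the first pair that isolates this position, and it shows that replacing the five-membered non-aromatic ring with an open dimethylamino group does not separate the two compounds in this read-out, so at this level of resolution the two groups cannot be told apart here. No supporting measurement bears on this result, so nothing can be said about what lies behind it.

Open, going by these compounds, is whether a different group on this ring carbon, such as piperidin-1-yl, morpholin-4-yl or a primary amine, would shift the number beyond the scatter, since two closely related tertiary amines cover only a narrow part of the possible range. Also open, on these data alone, is whether the same exchange would read alike on the core of compound 1, whose chain to the methylpiperazine carries no ester.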